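Methyl for hydrogen on the aryl ring of compound 3

The source may report more compounds than this note shows. Statements on the series, on what has been measured and on what is new or still open speak of the compounds shown alone.

The series is run in a functional assay on HEK293 cells for agonist activity at trace amine-associated receptor 1 (Homo sapiens), read by cAMP accumulation, with a stated time of 30 min; a lower number here means that less compound is needed, a higher number that more compound is needed for the effect. Compound 1 `NC1=N[C@@H](c2ccccc2Cl)CO1` gives 23 nM, compound 2 `C[C@]1(CCc2cccc(Cl)c2)COC(N)=N1` gives 330 nM, and compound 3 `NC1=N[C@@H](c2ccccc2)CO1` gives 67 nM. Compound 3 thus stands second highest of the three numbers, nearest to compound 1 and furthest from compound 2. Going by the values given here, the one single-point step in hand is a 2.9-fold higher number from compound 1 to compound 3 (0.46 log units; beyond the scatter), a modest rise. Compound 4 `Cc1ccccc1[C@H]1COC(N)=N1` differs from compound 3 by methyl in place of hydrogen on an aromatic carbon. Methyl enters at the aromatic carbon where compound 1 carries chloro, so that step is the one that bears here; run in reverse it points to a lower number for compound 4, of similar size. Compound 4 is therefore expected to give 30 nM, within a range from 12 nM to 75 nM. The expected step is a 2.2-fold lower number from compound 3 to compound 4 (0.35 log units; beyond the scatter).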

Compound 4, half-maximal effective concentration: 67 nM
For compound 4 the middle estimate is 2.2-fold (0.35 log units) below the measured one; low and high end bracket the measured number.
By their numbers in this assay, from the lowest: compound 1; then compounds 3 and 4 (each within the scatter of the next); then compound 2.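

In this assay, methyl on this aromatic carbon gives no change at the digits printed from compound 3 to compound 4 (within the scatter), so the lower number seen with chloro at the same carbon does not carry over to methyl. The two groups part here, a 2.9-fold higher number from compound 1 to compound 4 (0.46 log units; beyond the scatter), which shows that replacing hydrogen at this carbon does not by itself lower the number. Nothing in hand explains the difference between chloro and methyl.

From the compounds shown here alone, whether fluoro, methoxy or ethyl at this carbon would track chloro or methyl remains open. So does the outcome of chloro or methyl on the other aromatic carbons of the ring.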